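Para-Substituent Swap on the Benzoate Ring of the Diarylurea Series

This account rests on a few compounds, and the source may have more. Where it says the series, first, only, none or still open, it means among the compounds named here.

Measured so far:
Compound 1, `O=C(Nc1ccccc1)Nc1ccc(OC(=O)c2ccccc2)cc1`, 81200 nM in a functional assay on A549 cells (Homo sapiens) for antiproliferative activity, read by MTT assay, with a stated time of 48 h; a higher number here means a weaker inhibitor, a lower number a stronger inhibitor.
Compound 2, `O=C(Nc1ccccc1)Nc1ccc(OC(=O)c2ccc([N+](=O)[O-])cc2)cc1`, 120000 nM in this assay.

Compound 2 gives the highest of the two numbers, with compound 1 nearest; the step of a 1.5-fold higher number from compound 1 to compound 2 (0.17 log units; within the scatter) lies within the scatter. Compound 3, `O=C(Nc1ccccc1)Nc1ccc(OC(=O)c2ccc(F)cc2)cc1`, differs from compound 2 by fluoro in place of nitro on an aromatic carbon. Among the measured compounds shown here, the only step that bears on this change is the one from compound 1 to compound 2, which was within the scatter, so no shift beyond the scatter is expected, with the estimated step of a 1.3-fold lower number from compound 2 to compound 3 (0.12 log units; within the scatter). Compound 3 is therefore expected at 90000 nM, within the range 40000 nM to 200000 nM.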

Compound 3, half-maximal inhibitory concentration: 38500 nM
The estimate for compound 3 lay 2.3-fold (0.37 log units) above the measured number, and the stated range ends above it.
By their numbers in this assay, from the lowest: compound 3; then compounds 1 and 2 (each within the scatter of the next).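

In this assay this position, para to a large group, responds to the choice of substituent: fluoro gives a 3.1-fold lower number from compound 2 to compound 3 (0.49 log units; beyond the scatter) and a 2.1-fold lower number from compound 1 to compound 3 (0.32 log units; beyond the scatter) as modest steps beyond the scatter, whereas nitro in compound 2 stayed within the scatter of compound 1. Among the compounds shown here, compound 3 thus holds the lowest number of the three, and the position is the first to show a change beyond the scatter. Going by these compounds, whether chlorine, methoxy or an amine at this carbon would track with fluoro or with nitro remains open. No evidence available here accounts for the difference between fluoro and nitro.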